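Will compound 3 last longer?

This account rests on a few compounds, and the source may have more. Where it says the series, first, only, none or still open, it means among the compounds named here.

Compound 1 `CCOC(=O)[C@H](CCC(=O)C=[N+]=[N-])NC(=O)OCc1oc(=O)oc1C` gives 0% in this test
Compound 2 `Cc1oc(=O)oc1COC(=O)N[C@@H](CCC(=O)C=[N+]=[N-])C(=O)OC(C)C` gives 0% in this test

In an ADME assay on a cell-free system (plasma, Mus musculus) for metabolic stability, read by LC-MS, with a stated time of 60 min, tested at 10 uM (a lower number here means that less of the compound is left, a higher number that more of the compound is left), compound 2 gives 0% (level with compound 1) so none of it is detected at the end. Compound 3 `CC(C)OC(=O)[C@H](CCC(=O)C=[N+]=[N-])NC(=O)OCOC(=O)C(C)(C)C` differs from compound 2 at one place (a group of 7 heavy atoms (5 carbon, 2 oxygen; no ring) in place of a group of 7 heavy atoms (4 carbon, 3 oxygen; one five-membered aromatic ring with 2 hetero atoms), on a saturated chain carbon bound to an oxygen next to a carbonyl group). There, ((tert-butyl)carbonyl)oxy replaces the group with the five-membered aromatic ring, on a saturated chain carbon bound to an oxygen next to a carbonyl group. Among the measured compounds shown here, only one measured step exists, no change at the digits printed from compound 1 to compound 2 (within the scatter), and it is a methyl in place of a hydrogen rather than this exchange. For the measured compounds named here, it offers weak guidance, and no measured compound carries the new group. With nothing pointing to survival, the expected change is small, a number 3 percentage points higher from compound 2 to compound 3 (within the scatter), and none beyond the scatter. Compound 3 is estimated at 3% (expected range 0% to 15%).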

Compound 3, percent of the compound remaining: 0%
Estimate against measurement, compound 3: 3 percentage points above; the measured number falls inside the stated range.
By their numbers in this assay, from the lowest: compounds 1, 2 and 3 (each within the scatter of the next).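

In this assay, replacing the group with the five-membered aromatic ring by ((tert-butyl)carbonyl)oxy, on a saturated chain carbon bound to an oxygen next to a carbonyl group, gives no change at the digits printed from compound 2 to compound 3 (within the scatter). This place has now carried two different groups, one with a ring and one without, and neither leaves any compound detectable at the end of the test, whereas the earlier step only put a methyl in place of a hydrogen. Nothing measured here offers an explanation for this result.

With every reading at the bottom of the scale, the compounds shown leave open whether they vanish at similar or very different speeds. Also open, going by these compounds, is whether a plain methyl or a longer carbon chain at this place would leave any compound behind.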